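The compounds below may be only part of what the source reports. "The series", "measured", "known", "first", "only" and "open" are said of these compounds alone.

In an ADME assay on HEK293 cells (Homo sapiens) for cytotoxicity, read by reporter gene assay and resazurin assay, with a stated time of 48 h (a lower number here means that less compound is tolerated, a higher number that more compound is tolerated), compound 3 (`COc1c(Br)cc(Br)cc1C(=O)Nc1ccc(Sc2nc3ccccc3s2)c(Cl)c1`) gives > 100000 nM, which is a limit of the assay and not a number. Compound 1 (`COc1c(Br)cc(Br)cc1C(=O)Nc1ccccc1`) gives > 100000 nM, also a limit. Together they make up (the limit of > 100000 nM in this assay, at which 2 of the 3 values shown sit). Compound 2 (`O=C(Nc1cccc(Cl)c1)c1cc(Br)cc(Br)c1`) gives a measured number, 53000 nM. Compound 4 (`COc1c(Br)cc(Br)cc1C(=O)Nc1cccc(Cl)c1`) differs from compound 3 as follows: hydrogen in place of (1,3-benzothiazol-2-yl)sulfanyl on an aromatic carbon. In words, hydrogen takes the place of (1,3-benzothiazol-2-yl)sulfanyl on an aromatic carbon, and the chloro group stays. That chloro group also occurs in compound 2, which gives 53000 nM, so a modest fall in tolerated concentration seems possible. The expected change in this assay is small, an estimated at least 1.2-fold lower number from compound 3 to compound 4 (0.09 log units; that floor lies within the scatter), and may stay within the scatter. For compound 4 the estimate is 80000 nM, with an expected range from 35000 nM to 150000 nM.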

Compound 4, half-maximal cytotoxic concentration: > 100000 nM
Compound 4: only a limit was reported (the forecaster's own chance of this, stated with the estimate: 45%); middle value at least 1.2-fold (0.09 log units) from the limit.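

Losing the (1,3-benzothiazol-2-yl)sulfanyl group while keeping the chloro group brings out no measurable cytotoxicity, as compound 4 still gives only a limit of the assay. In this assay, within the data shown here, methoxy in place of hydrogen gives an at least 1.8-fold higher number from compound 2 to compound 4 (0.27 log units; that floor lies within the scatter), the only step here that can be read. The steps to compound 4 from compound 3 and from compound 1 cannot be read, with a limit at both ends: the limit of > 100000 nM in this assay, at which 3 of the 4 values shown sit.

From the compounds shown here alone, whether methoxy truly raises the tolerated concentration stays open, since only a floor is known. Also open, going by these compounds, is whether an amine or a carboxylic acid in place of the (1,3-benzothiazol-2-yl)sulfanyl group would give a measurable number.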